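Hydroxy for trifluoromethyl on a trimethoxyphenyl pyrazole core

This account rests on a few compounds, and the source may have more. Where it says the series, first, only, none or still open, it means among the compounds named here.

Measured so far in a functional assay on U-87MG ATCC cells (Homo sapiens) for antiproliferative activity, read by MTT assay, with a stated time of 48 h; on this read-out higher numbers stand for weaker inhibition and lower numbers for stronger inhibition:
compound 1, `O=C(/C=C\Nc1ccc(C(F)(F)F)cc1)c1cn(-c2ccccc2)nc1-c1ccc(Cl)cc1`, gives > 50000 nM, a limit of the assay;
compound 2, `O=C(/C=C\Nc1ccc(O)cc1)c1cn(-c2ccccc2)nc1-c1ccc(Cl)cc1`, gives 1500 nM;
compound 3, `COc1cc(-c2nn(-c3ccccc3)cc2C(=O)/C=C\Nc2ccc(C(F)(F)F)cc2)cc(OC)c1OC`, gives > 50000 nM, again a limit of the assay.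

Compound 1 and compound 2 differ by hydroxy in place of trifluoromethyl on an aromatic carbon. This change gave an at least 33-fold lower number from compound 1 to compound 2 (1.52 log units; beyond the scatter). Two of the three values shown sit at the limit of > 50000 nM in this assay, at which 2 of the 3 values shown sit, so the step from compound 1 to compound 2 can only be read as a lower bound.

Compound 3 carries a different core: compound 1 and compound 3 differ by 3,4,5-trimethoxyphenyl in place of 4-chlorophenyl on an aromatic carbon, and this gave a step that the two limits leave unreadable from compound 1 to compound 3.

Compound 4, `COc1cc(-c2nn(-c3ccccc3)cc2C(=O)/C=C\Nc2ccc(O)cc2)cc(OC)c1OC`, is not yet measured. It differs from compound 3 by hydroxy in place of trifluoromethyl on an aromatic carbon, the same change as from compound 1 to compound 2, at the same place. On the trimethoxyphenyl core the step is expected to be an at least 16-fold lower number from compound 3 to compound 4 (1.22 log units; beyond the scatter), because the parallel step was an at least 33-fold lower number from compound 1 to compound 2 (1.52 log units; beyond the scatter) while compound 3 starts from a limit. Compound 4 is therefore estimated at 3000 nM, between 700 nM and 30000 nM, in this assay.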

Compound 4, half-maximal inhibitory concentration: 1800 nM
The estimate for compound 4 lay 1.7-fold (0.22 log units) above the measured number; measured number inside the range.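

In this assay, hydroxy in place of trifluoromethyl gave an at least 27-fold lower number from compound 3 to compound 4 (1.44 log units; beyond the scatter), so the change lowered the number on the core of compound 3 as it had on the core of compound 1. This shows that the direction of the step carried over between these two cores, but it does not show that the step has the same size on both, because each trifluoromethyl compound sits at a limit of the assay: the limit of > 50000 nM in this assay, at which 2 of the 4 values shown sit. As far as these compounds go, each step is therefore only a lower bound, and the comparison between them stays open: the same change on two cores in this assay, an at least 33-fold lower number (1.52 log units; beyond the scatter) from compound 1 to compound 2 and an at least 27-fold lower number (1.44 log units; beyond the scatter) from compound 3 to compound 4; the limit leaves it open whether they differ.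

The compounds shown leave open whether the large step belongs to hydroxy specifically or would also follow from an amine or a carboxylic acid at the same place. They also leave open whether the step would carry over to a third core, for instance one with an unsubstituted phenyl in place of 4-chlorophenyl or 3,4,5-trimethoxyphenyl.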